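This account rests on a few compounds, and the source may have more. Where it says the series, first, only, none or still open, it means among the compounds named here.

Of the compounds shown here, three have so far been tested in a functional assay on MIA PaCa-2 cells (Homo sapiens) for inhibition, read by MTT assay, with a stated time of 72 h (a lower number here means a stronger inhibitor, a higher number a weaker inhibitor), and none of them gave a number. Compound 1 `Cc1ccc(S(=O)(=O)Nc2cc[nH]c(=O)n2)cc1` stopped at the limit of the assay, > 100000 nM. Compound 2 `O=c1ccn(COC(CO)CO)c(=O)[nH]1` also stopped at the limit, with > 100000 nM. Compound 3 `Nc1cn(COC(CO)CO)c(=O)[nH]c1=O` differs from compound 2 by an amino in place of hydrogen on an aromatic carbon. Compound 3 again returned only a limit, > 100000 nM. So compound 3 stands where every tested compound stands: at the edge of what this assay can report, as summarised by the limit of > 100000 nM in this assay, at which 3 of the 3 values shown sit. Going by the values given here, the single measured step, a step that the two limits leave unreadable from compound 2 to compound 3, is for that reason unreadable and gives no sense of how far a small change on the shared core moves the number.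

Compound 4 `O=C(CCl)Nc1cn(COC(CO)CO)c(=O)[nH]c1=O` is the next compound, and it differs from compound 3 by (chloromethyl)carbonyl in place of hydrogen on a nitrogen on an aromatic ring. Among the compounds with values here, the only step that touches the same part of the core is the unreadable one from compound 2 to compound 3, so no measured step predicts a direction or a size here. On the numbers available, the expectation for compound 4 is that it stays close to the limit, and the step of an at least 1.2-fold lower number from compound 3 to compound 4 (0.09 log units; that floor lies within the scatter) is estimated as small. Compound 4 is therefore expected to give about 80000 nM, with a range from 20000 nM to 300000 nM.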

Compound 4, half-maximal inhibitory concentration: 18000 nM
Compound 4: the middle estimate sits 4.4-fold (0.65 log units) above what was measured; measured number below the stated range.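

In this assay, going by these compounds alone, the change from amino to ((chloromethyl)carbonyl)amino gives the first readable step, an at least 5.5-fold lower number from compound 3 to compound 4 (0.74 log units; beyond the scatter). Set against the hydrogen at the same place, the whole ((chloromethyl)carbonyl)amino group gives a step of the same kind, an at least 5.5-fold lower number from compound 2 to compound 4 (0.74 log units; beyond the scatter), while the step between the two compounds that both sit at a limit cannot be read. This shows that a change on this nitrogen can bring a compound on the shared core into the range the assay can report, and compound 4 is the one compound that has a true number rather than a limit: the limit of > 100000 nM in this assay, at which 3 of the 4 values shown sit.

The comparison with an acetyl group in the same place, which has no chlorine, would show whether the chlorine matters or the carbonyl alone is enough, and a longer chain carrying the chlorine would show whether the distance between the two counts. Also open, as far as these compounds go, is the true size of both steps, as each starts from a limit and so gives only a minimum.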